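From 4-methoxyphenyl to phenethyl on the carbonyl carbon

The compounds below may be only part of what the source reports. "The series", "measured", "known", "first", "only" and "open" are said of these compounds alone.

- compound 1 `Cc1ccc(C(=O)Oc2ccc(/C=C3\CCCCC3=O)cc2)cc1`: 25600 nM
- compound 2 `COc1ccc(C(=O)Oc2ccc(/C=C3\CCCCC3=O)cc2)cc1`: 34000 nM

Among the compounds with values here, in a functional assay on MOLT-4 cells (Homo sapiens) (on this read-out lower numbers stand for stronger inhibition and higher numbers for weaker inhibition), compound 2 gives 34000 nM, which cannot be told apart from the only other measured value. Compound 3 `O=C(CCc1ccccc1)Oc1ccc(/C=C2\CCCCC2=O)cc1` differs from compound 2 as follows: phenethyl in place of 4-methoxyphenyl on a carbonyl carbon. Within the data shown here, the one measured step, a 1.3-fold higher number from compound 1 to compound 2 (0.12 log units; within the scatter), bears on this only loosely, since it is methoxy in place of methyl on an aromatic carbon. Among the measured compounds shown here, no measured step changes the group on the carbonyl carbon. In this assay no step beyond the scatter is therefore expected, in either direction, though with wide uncertainty. The expected step is a 1.2-fold lower number from compound 2 to compound 3 (0.08 log units; within the scatter). Compound 3 is estimated at 28000 nM, with an expected range of 11000 nM to 70000 nM.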

Compound 3, half-maximal inhibitory concentration: 31100 nM
Compound 3: the middle estimate sits 1.1-fold (0.05 log units) below what was measured; the measured number falls inside the stated range.
By their numbers in this assay, from the lowest: compounds 1, 3 and 2 (each within the scatter of the next).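

Replacing the aromatic group on the carbonyl carbon with phenethyl leaves this assay within the scatter, with a 1.1-fold lower number from compound 2 to compound 3 (0.04 log units; within the scatter) and a 1.2-fold higher number from compound 1 to compound 3 (0.08 log units; within the scatter). On this carbonyl carbon, phenethyl, 4-methoxyphenyl and 4-methylphenyl cannot be told apart, and losing the hydrogen-bond acceptor of 4-methoxyphenyl brings no readable change. No evidence is available on why these values coincide. On these data alone, all three groups carry a six-membered aromatic ring, so a linear alkyl chain or a carboxylic acid at this position remains open. As far as these compounds go, whether any group here moves the number beyond the scatter also remains open.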